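The source may report more compounds than this note shows. Statements on the series, on what has been measured and on what is new or still open speak of the compounds shown alone.

Measured so far:

Compound 1, `CC[C@@H](NC(=O)CC(C)C)C(=O)N1CCC(c2ccc(Cl)cc2)CC1`, gives 152 nM in an assay on THP-1 cells for displacement of a labelled ligand from C-C chemokine receptor type 1 (Homo sapiens); on this read-out lower numbers stand for stronger inhibition and higher numbers for weaker inhibition.
Compound 2, `CC[C@@H](C)[C@@H](NC(=O)c1ccccc1)C(=O)N1CCC(c2ccc(Cl)cc2)CC1`, gives 45 nM in this assay.
Compound 3, `CC[C@@H](C)[C@@H](NC(=O)CCc1ccccc1)C(=O)N1CCC(c2ccc(Cl)cc2)CC1`, gives 66 nM in this assay.

Compound 3 stands second highest of the three numbers in this assay. Its nearest neighbour is compound 2, which sits within the scatter of it; compound 1 lies furthest away, beyond the scatter. Going by the values given here, the one measured step in this set, a 1.5-fold higher number from compound 2 to compound 3 (0.17 log units; within the scatter), replaces phenyl with phenethyl on the carbonyl carbon and stays within the scatter.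

Compound 4, `CC[C@@H](C)[C@@H](NC(=O)CC(C)C)C(=O)N1CCC(c2ccc(Cl)cc2)CC1`, is not yet measured. It differs from compound 3 by isopropyl in place of benzyl on a saturated chain carbon bound to a carbonyl carbon. Among the compounds with values here, no measured step shows the same change. Within the data shown here, the only step that touches the acyl group, a 1.5-fold higher number from compound 2 to compound 3 (0.17 log units; within the scatter), tells that exchanging one aromatic acyl group for another leaves the number within the scatter, but it says nothing about the loss of the aromatic ring. Compound 1, which carries the isobutylcarbonyl group but a different side chain, gives 152 nM, a higher number than compound 3 beyond the scatter. On that basis compound 4 is expected to land between the two, so a 1.5-fold higher number from compound 3 to compound 4 (0.18 log units; within the scatter) is the estimated step. Compound 4 is estimated at 100 nM, with a range from 45 nM to 250 nM.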

Compound 4, half-maximal inhibitory concentration: 34 nM
For compound 4 the middle estimate is 2.9-fold (0.47 log units) above the measured one, and the stated range ends above it.
By their numbers in this assay, from the lowest: compounds 4, 2 and 3 (each within the scatter of the next); then compound 1.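

In this assay the aromatic ring of the acyl group proves dispensable among these compounds: isopropyl in place of benzyl on a saturated chain carbon bound to a carbonyl carbon gives a 1.9-fold lower number from compound 3 to compound 4 (0.29 log units; within the scatter) and isobutyl in place of phenyl on a carbonyl carbon gives a 1.3-fold lower number from compound 2 to compound 4 (0.12 log units; within the scatter), so phenylcarbonyl, phenethylcarbonyl and isobutylcarbonyl cannot be told apart at this position. Going by these compounds alone, the only new step beyond the scatter lies away from the acyl group, where, with isobutylcarbonyl held constant, ethyl in place of hydrogen on a saturated chain carbon bound to two saturated chain carbons gives a 4.5-fold lower number from compound 1 to compound 4 (0.65 log units; beyond the scatter), a modest change. Nothing available explains why the acyl group can lose its ring with the number staying within the scatter, or why the added ethyl comes with a lower number.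

On these data alone, whether an amine or a carboxylic acid on the acyl chain, or a longer chain there, would also stay within the scatter remains open. The compounds shown also share the same core, so what a methoxy group in place of its chlorine would do remains unknown.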